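A few compounds are considered here, and "the series" means these few. Any claim that something is new, unique, unknown or untested is made for them only; others in the source may bear on it.

Compounds measured in an assay on isolated protein for inhibition of Nitric oxide synthase, inducible (Homo sapiens), read by spectrophotometry, using NADPH, tested at 1 mM, in the presence of a further agent that is not named here; a higher number here means more inhibition at the concentration tested (going by the name of the read-out), a lower number less inhibition:
compound 1, `C=CCCNC(=N)NCCCCN`, gives 23%;
compound 2, `COCC(=N)NCCC[C@H](N)C(=O)O`, gives 75%;
compound 3, `COCC(=N)NCCCCN`, gives 42%.

Compound 3 stands second among the three numbers in this assay, behind compound 2 and ahead of compound 1, both gaps beyond the scatter. Compound 4, `COCCCC(=N)NCCCCN`, has not been measured; it differs from compound 3 by 2-methoxyethyl in place of methoxy on a saturated chain carbon bound to a carbon with a double bond to nitrogen. Among the compounds with values here, the one step that has been measured, a number 33 percentage points lower from compound 2 to compound 3 (beyond the scatter), concerns a different site and is large, so it gives no direct guide here. Within the data shown here, compounds 1 and 3 carry different groups at the site in question and their values differ, but no step between them is defined. With no comparable chain extension measured, a modest change in either direction is expected, estimated as a number 5 percentage points lower from compound 3 to compound 4 (within the scatter). Compound 4 is therefore estimated at 37%, within 12% to 62%.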

Compound 4, a percentage reported as inhibition, at one concentration (the size of the read-out at that concentration, not a potency): 15%
Compound 4: the middle estimate sits 22 percentage points above what was measured; low and high end bracket the measured number.
By their numbers in this assay, from the lowest: compounds 4 and 1 (each within the scatter of the next); then compound 3; then compound 2.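

Going from methoxy to 2-methoxyethyl on a saturated chain carbon bound to a carbon with a double bond to nitrogen gives a number 27 percentage points lower from compound 3 to compound 4 (beyond the scatter) in this assay. This shows that inhibition responds to the group at this position, which the earlier step, at the carboxy site, could not show, and that here the longer group goes with the lower number. Nothing measured here accounts for the fall.

From the compounds shown here alone, whether an amine or a hydroxymethyl group at this position would keep more inhibition remains open. So does whether the same change would cost as much on the core of compound 2, which carries the carboxy group.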